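Dropping the bromo from a weakly active diaryl urea

A few compounds are considered here, and "the series" means these few. Any claim that something is new, unique, unknown or untested is made for them only; others in the source may bear on it.

In a functional assay (thoracic aorta, Rattus norvegicus, strain Wistar) (a lower number here means that less compound is needed, a higher number that more compound is needed for the effect), compound 1 `CC(C)(C)NC(=O)Nc1nc2ccc(Br)cc2s1` gives 13000 nM, and compound 3 `CC(C)(C)NC(=O)Nc1nc2ccc([N+](=O)[O-])cc2s1` gives 10800 nM. Within the data shown here, the one measured step between them, a 1.2-fold lower number from compound 1 to compound 3 (0.08 log units; within the scatter), shows that swapping one substituent for another on that ring made no difference that counts. Compound 2 `O=C(Nc1nc2ccc(Br)cc2s1)Nc1ccc(C(F)(F)F)cc1Cl` carries a different group on the urea and behaves differently: in this assay compound 2 gives only a limit, > 100000 nM, not a number. Compound 2 therefore sits at the weak end of the three values shown, at the limit of > 100000 nM in this assay, at which 1 of the 3 values shown sits.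

Compound 4 `O=C(Nc1nc2ccccc2s1)Nc1ccc(C(F)(F)F)cc1Cl` differs from compound 2 in one place: hydrogen in place of bromo on an aromatic carbon. No measured step removes this bromo, so none of the steps shown bears directly on this change; the only measured step, a 1.2-fold lower number from compound 1 to compound 3 (0.08 log units; within the scatter), replaces the bromo with nitro and stays within the scatter. From the compounds shown here alone, because compound 2 gives only the limit > 100000 nM, the starting point itself is unknown beyond that limit, and the expected step of a number no higher from compound 2 to compound 4 (the limit leaves the size open) is set at none beyond the scatter. Compound 4 is expected to give 100000 nM, within a range from 30000 nM to 300000 nM, and most likely again only a limit.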

Compound 4, half-maximal effective concentration: > 100000 nM
Compound 4 ended at the assay's limit; the forecaster's own chance of this, stated with the estimate: 70%; the middle value sits exactly at the limit.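

In this assay compound 2 and compound 4 each give only a limit, not a number, so the step between them, hydrogen in place of bromo, cannot be read: the limit of > 100000 nM in this assay, at which 2 of the 4 values shown sit. The compounds shown leave open whether removing the bromo changes the effect at all, and how much of either compound the effect would take.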